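A few compounds are considered here, and "the series" means these few. Any claim that something is new, unique, unknown or untested is made for them only; others in the source may bear on it.

Measured so far:
Compound 1 `O=C([C@@H]1CCCN(S(=O)(=O)c2ccc(S(=O)(=O)C3COC3)cc2)C1)N1CCC(F)(F)CC1`: 361 nM
Compound 2 `CN(C)S(=O)(=O)c1ccc(S(=O)(=O)N2CCC[C@@H](C(=O)N3CCC(F)(F)CC3)C2)cc1`: 560 nM

Among the measured compounds shown here, in a functional assay on BXPC-3 cells (Homo sapiens) for inhibition, read by MTT assay, with a stated time of 7 days (a lower number here means a stronger inhibitor, a higher number a weaker inhibitor), compound 2 gives 560 nM; the only other measurement, compound 1 at 361 nM, is separated from it by a 1.6-fold higher number from compound 1 to compound 2 (0.19 log units; within the scatter), a gap that counts as no real difference. Compound 3 `O=C([C@@H]1CCCN(S(=O)(=O)c2ccc(S(=O)(=O)N3CC[C@H](O)C3)cc2)C1)N1CCC(F)(F)CC1` differs from compound 2 by 3-hydroxypyrrolidin-1-yl in place of dimethylamino on a sulfonyl sulfur. For the measured compounds named here, the one measured step at this sulfonyl position, a 1.6-fold higher number from compound 1 to compound 2 (0.19 log units; within the scatter), lay within the scatter, so a swap of the same kind gives no basis to expect a step beyond it in this assay. Compound 3 is therefore expected near 450 nM, within a range from 180 nM to 1100 nM. The estimated step, a 1.2-fold lower number from compound 2 to compound 3 (0.09 log units; within the scatter), stays within the scatter.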

Compound 3, half-maximal inhibitory concentration: 580 nM
Compound 3: middle estimate off by 1.3-fold (0.11 log units), on the low side; the measured number falls inside the stated range.
By their numbers in this assay, from the lowest: compounds 1, 2 and 3 (each within the scatter of the next).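

In this assay, 3-hydroxypyrrolidin-1-yl in place of dimethylamino gives a 1.0-fold higher number from compound 2 to compound 3 (0.02 log units; within the scatter), and the same group in place of oxetan-3-yl gives a 1.6-fold higher number from compound 1 to compound 3 (0.21 log units; within the scatter). On this sulfonyl sulfur, then, a swap that brings in a five-membered ring, a hydrogen-bond donor and a defined stereocentre still leaves all three compounds within the scatter of one another. No evidence is available that bears on this result. As far as these compounds go, it remains open whether plain pyrrolidin-1-yl, or a group carrying a carboxylic acid, on this sulfur would read the same or move the number beyond the scatter.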